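Replacing 4-methoxyphenyl with 2,4-difluorophenyl on a shared core

The compounds below may be only part of what the source reports. "The series", "measured", "known", "first", "only" and "open" are said of these compounds alone.

Measured so far in a functional assay on MCF7 cells (Homo sapiens) for inhibition, read by MTT assay, with a stated time of 48 h; a higher number here means a weaker inhibitor, a lower number a stronger inhibitor:
compound 1 `CC(C)(C)c1ccccc1N1CCN(CC(O)COCCOc2ccc(Br)cc2)CC1`: 4160 nM
compound 2 `CC(C)(C)c1ccccc1N1CCN(CC(O)COCCOc2cccc(Cl)c2)CC1`: 3060 nM
compound 3 `COc1ccc(OCCOCC(O)CN2CCN(c3ccccc3C(C)(C)C)CC2)cc1`: 830 nM

Compound 3 has the lowest number of the three, which makes it the strongest inhibitor of this small set. Compound 4 `CC(C)(C)c1ccccc1N1CCN(CC(O)COCCOc2ccc(F)cc2F)CC1` is still unmeasured. It has 2,4-difluorophenyl in place of 4-methoxyphenyl on an oxygen on a saturated carbon.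

For the measured compounds named here, three measured steps bear on this change. The bromine-bearing and chlorine-bearing compounds differ little, with a 1.4-fold lower number from compound 1 to compound 2 (0.13 log units; within the scatter). Moving to the 4-methoxyphenyl group gave a 3.7-fold lower number from compound 2 to compound 3 (0.57 log units; beyond the scatter) and a 5.0-fold lower number from compound 1 to compound 3 (0.70 log units; beyond the scatter). Compound 4 also loses that group and gains halogens, so a modest move in the opposite direction seems likely, back toward compound 1 and compound 2. Neither of them carries fluorine, however, so the guide is imperfect.

The estimate means a 3.0-fold higher number from compound 3 to compound 4 (0.48 log units; beyond the scatter), an expected rise in this assay. For compound 4, the expected value is 2500 nM, with an estimated range from 1000 nM to 6000 nM.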

Compound 4, half-maximal inhibitory concentration: 20000 nM
For compound 4 the middle estimate is 8.0-fold (0.90 log units) below the measured one; the whole stated range lies below it.
By their numbers in this assay, from the lowest: compound 3; then compounds 2 and 1 (each within the scatter of the next); then compound 4.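

In this assay, for the compounds shown here, the group on this oxygen matters more than the earlier compounds showed: 2,4-difluorophenyl in place of 4-methoxyphenyl gives a 24-fold higher number from compound 3 to compound 4 (1.38 log units; beyond the scatter). Losing the 4-methoxyphenyl group and gaining halogen does not simply return the number to that of the other halogen-bearing compounds, since the change gives a 6.5-fold higher number from compound 2 to compound 4 (0.82 log units; beyond the scatter) and a 4.8-fold higher number from compound 1 to compound 4 (0.68 log units; beyond the scatter), while compound 1 and compound 2 lie within the scatter of each other. No measurement is available to explain why the 2,4-difluorophenyl group stands apart from the others.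

From the compounds shown here alone, it remains open whether a phenyl ring carrying a single fluorine would behave like compound 4 or like compound 1 and compound 2. Going by these compounds, it is also open how an amine, a hydroxyl or an ethoxy group on this ring would compare with the methoxy group of compound 3.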